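This account rests on a few compounds, and the source may have more. Where it says the series, first, only, none or still open, it means among the compounds named here.

Compound 1 `COc1nc(N)nc2c1c(-c1cc3ccccc3o1)cn2[C@@H]1O[C@H](CO)[C@@H](O)[C@H]1O` carries a methoxy group, an amino group and a 1-benzofuran-2-yl group on a shared core that also bears the sugar. In a functional assay on A549 cells (Homo sapiens), read by MTT assay, with a stated time of 72 h (a lower number here means a stronger inhibitor, a higher number a weaker inhibitor), compound 1 gives > 20000 nM, which is a limit of the assay rather than a measured number. It is accompanied by compound 2 `Nc1nc(N)c2c(-c3cc4ccccc4o3)cn([C@@H]3O[C@H](CO)[C@@H](O)[C@H]3O)c2n1` and compound 3 `COc1ncnc2c1c(-c1cc3ccccc3o1)cn2[C@@H]1O[C@H](CO)[C@@H](O)[C@H]1O`. In this assay compound 2 gives > 20000 nM, again a limit. In this assay compound 3 gives 17700 nM. Hence the step that the two limits leave unreadable from compound 1 to compound 2 cannot be read, and the step of an at least 1.1-fold lower number from compound 1 to compound 3 (0.05 log units; that floor lies within the scatter) stays within the scatter. Compound 1 thus stands at the limit of > 20000 nM in this assay, at which 2 of the 3 values shown sit, and nothing among the shown values sets it apart from compound 2 or compound 3.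

Compound 4 `COc1nc(N)nc2c1c(-c1ccco1)cn2[C@@H]1O[C@H](CO)[C@@H](O)[C@H]1O` differs from compound 1 in one place: furan-2-yl in place of 1-benzofuran-2-yl on an aromatic carbon. Among the compounds with values here, neither measured step concerns the 1-benzofuran-2-yl group; both exchange a small group on an aromatic carbon, and both are either unreadable or within the scatter, so no measured step gives a size for this change. Compound 4 is therefore expected to remain a weak inhibitor, with the step that the limit leaves unreadable from compound 1 to compound 4 expected to be small. Compound 4 is estimated at about 30000 nM, in the range 10000 nM to 100000 nM, and will most likely be reported only as a limit.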

Compound 4, half-maximal inhibitory concentration: > 20000 nM
Compound 4: only a limit was reported; the forecaster's own chance of this, stated with the estimate: 70%; the middle value is on the limit's open side.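

In this assay compound 4 gives > 20000 nM, which is a limit of the assay. Compound 1 also stands at a limit, so the change from compound 1 to compound 4 cannot be read. The compounds shown leave open how furan-2-yl and 1-benzofuran-2-yl compare on the shared core, with most values resting at one point: the limit of > 20000 nM in this assay, at which 3 of the 4 values shown sit.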